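Amide group swap from compound 3 to compound 4

The compounds below may be only part of what the source reports. "The series", "measured", "known", "first", "only" and "open" are said of these compounds alone.

Three amides on a shared core have numbers in a functional assay on HCT-116 cells (Homo sapiens) for cytotoxicity, read by sulforhodamine B assay, with a stated time of 72 h; on this read-out lower numbers stand for stronger inhibition and higher numbers for weaker inhibition. Compound 1 `Cc1ccc(-c2cc(C(=O)Nc3ccncc3)nn2-c2ccc3ccccc3n2)cc1` gives 8100 nM, compound 2 `Cc1ccc(-c2cc(C(=O)Nc3ccnc(Cl)c3)nn2-c2ccc3ccccc3n2)cc1` gives 1100 nM and compound 3 `Cc1ccc(-c2cc(C(=O)Nc3ncc(Br)cc3Br)nn2-c2ccc3ccccc3n2)cc1` gives 9600 nM. Compound 3 sits at the weak end of this small set, level with compound 1 and apart from compound 2. The measured steps read a 1.2-fold higher number from compound 1 to compound 3 (0.07 log units; within the scatter) and an 8.7-fold higher number from compound 2 to compound 3 (0.94 log units; beyond the scatter).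

Compound 4 `Cc1ccc(-c2cc(C(=O)Nc3ccncc3Br)nn2-c2ccc3ccccc3n2)cc1` differs from compound 3 by 3-bromopyridin-4-yl in place of 3,5-dibromopyridin-2-yl on an amide-type nitrogen. This puts 3-bromopyridin-4-yl in place of 3,5-dibromopyridin-2-yl on an amide-type nitrogen, so compound 4 returns to the pyridin-4-yl family of compound 1 and compound 2. Within that family, chloro in place of hydrogen gave a 7.4-fold lower number from compound 1 to compound 2 (0.87 log units; beyond the scatter), the only measured halogen gain. Within the data shown here, no measured compound carries the 3-bromopyridin-4-yl group, so that gain transfers only in part.

The expected step is a 3.2-fold lower number from compound 3 to compound 4 (0.51 log units; beyond the scatter), a modest move to a lower number. The estimate for compound 4 is 3000 nM, with an expected range of 900 nM to 9000 nM.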

Compound 4, half-maximal inhibitory concentration: 15500 nM
Compound 4: the middle estimate sits 5.2-fold (0.71 log units) below what was measured; measured number outside the range, above it.
By their numbers in this assay, from the lowest: compound 2; then compounds 1, 3 and 4 (each within the scatter of the next).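

In this assay, the added bromo group gives a 1.9-fold higher number from compound 1 to compound 4 (0.28 log units; within the scatter), so a halogen on the pyridin-4-yl ring does not by itself lower the number, and compound 2 goes against any such reading. The 2-chloropyridin-4-yl group remains apart from the 3-bromopyridin-4-yl group, with a 14-fold higher number from compound 2 to compound 4 (1.15 log units; beyond the scatter), whereas a 1.6-fold higher number from compound 3 to compound 4 (0.21 log units; within the scatter) leaves the 3-bromopyridin-4-yl and 3,5-dibromopyridin-2-yl amides unseparated. No supporting data account for the difference between the two halogenated pyridin-4-yl amides.

Still open, from the compounds shown here alone, is whether the halogen itself or where it sits separates compound 2 from compound 4; a 2-bromopyridin-4-yl or 3-chloropyridin-4-yl amide would settle this. Going by these compounds, whether a non-halogen group, such as the amine of a 2-aminopyridin-4-yl amide, would match chloro is also open.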